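Methyl in place of hydrogen on compound 3

The compounds below may be only part of what the source reports. "The series", "measured", "known", "first", "only" and "open" are said of these compounds alone.

In a functional assay on thoracic aorta (Rattus norvegicus, strain Wistar), with a stated time of 15 min (a higher number here means that more compound is needed for the effect, a lower number that less compound is needed), compound 1 `Cc1ccc(OCc2ccccc2)c(C(C)NC(=O)NS(=O)(=O)c2ccc(Cl)cc2)c1` gives 65300 nM and compound 2 `CC(NC(=O)NS(=O)(=O)c1ccc(Cl)cc1)c1ccccc1OCc1ccccc1` gives 157000 nM on the chloro-bearing side of the series. Compound 3 `CC(NC(=O)NS(=O)(=O)c1ccccc1)c1ccccc1OCc1ccccc1` has only a limit and no number in this assay, namely > 200000 nM.

Compound 4 `Cc1ccc(OCc2ccccc2)c(C(C)NC(=O)NS(=O)(=O)c2ccccc2)c1` differs from compound 3 by methyl in place of hydrogen on an aromatic carbon. Among the measured compounds shown here, the closest precedent is the same change in reverse, a 2.4-fold higher number from compound 1 to compound 2 (0.38 log units; beyond the scatter), a modest step. Going by these compounds, removing chloro gives an at least 1.2-fold higher number from compound 2 to compound 3 (0.10 log units; that floor lies within the scatter), so the starting point stays open. A modest move to a lower number is therefore expected, estimated as an at least 1.5-fold lower number from compound 3 to compound 4 (0.18 log units; that floor lies within the scatter). The estimate for compound 4 is 130000 nM, with an expected range of 70000 nM to 280000 nM.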

Compound 4, half-maximal effective concentration: > 200000 nM
Compound 4: only a limit was reported; the forecaster's own chance of this, stated with the estimate: 30%; middle value at least 1.5-fold (0.18 log units) away from the limit.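

On the methyl-bearing core, hydrogen in place of chloro in this assay gives an at least 3.0-fold higher number from compound 1 to compound 4 (0.48 log units; beyond the scatter), a floor that the pair without methyl did not reach. The methyl step between compound 3 and compound 4 cannot be read, as both values are limits. Methyl alone therefore gives no measured number without chloro, and compound 4 stays at the assay limit: the limit of > 200000 nM in this assay, at which 2 of the 4 values shown sit.

Going by these compounds, whether the chloro step truly differs between the two cores stays open: the same change on two cores in this assay, an at least 1.2-fold higher number (0.10 log units; that floor lies within the scatter) from compound 2 to compound 3 and an at least 3.0-fold higher number (0.48 log units; beyond the scatter) from compound 1 to compound 4; the limit leaves it open whether they differ Also open is whether an amine or a carboxylic acid in place of chloro would give a measured number.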